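The source may report more compounds than this note shows. Statements on the series, on what has been measured and on what is new or still open speak of the compounds shown alone.

Measured so far:

compound 1 `CCCc1nc(C)c2c(C)nn(CCC)c(=O)n12` — in a functional assay for inhibition, with Homo sapiens as the target (a higher number here means a weaker inhibitor, a lower number a stronger inhibitor), compound 1 gives > 48000 nM, a limit of the assay and not a number.
compound 2 `CCn1ncc2cncn2c1=S` — in this assay compound 2 gives > 48000 nM, again a limit.
compound 3 `C=CCn1ncc2cnc(-c3ccc(OC)cc3)n2c1=O` — in this assay compound 3 gives > 48000 nM, again a limit.

Compound 1 therefore stands nowhere on a scale of numbers: it sits at the limit of > 48000 nM in this assay, at which 3 of the 3 values shown sit, together with every other value in the series. Within the data shown here, no two measured compounds differ in one place only, so no measured step exists, and compounds 2 and 3 share neither the core nor the side chains of compound 1 closely enough to serve as a guide.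

The next compound, compound 4 `CCCc1nc(C)c2c(C)nn(Cc3ccccc3)c(=O)n12`, is compound 1 with phenyl in place of ethyl on a saturated chain carbon bound to an aromatic nitrogen. Among the measured compounds shown here, with no measured step and all values sitting at the limit, the expected step in this assay is none beyond the scatter: compound 4 is expected to remain at the limit as well, with only a modest chance of a measurable number. The estimate for compound 4 is 48000 nM, from 12000 nM to 200000 nM, an expected step of a number no higher from compound 1 to compound 4 (the limit leaves the size open).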

Compound 4, half-maximal inhibitory concentration: > 48000 nM
Compound 4 was reported as a limit; the forecaster's own chance of this, stated with the estimate: 70%; the middle value lies on the limit itself.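

In this assay compound 4 gives > 48000 nM, a limit of the assay and not a number. Compound 1 also stands at a limit, so no step can be read between compound 1 and compound 4. The compounds shown leave open whether any change in this series gives a measurable number: the limit of > 48000 nM in this assay, at which 4 of the 4 values shown sit.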